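Same Atoms, Two Stereocentres Redrawn

The compounds below may be only part of what the source reports. "The series", "measured", "known", "first", "only" and "open" are said of these compounds alone.

Measured in an in vitro ADME assay on microsomes (Mus musculus) for metabolic stability; a lower number here means that the compound disappears faster, a higher number that the compound lasts longer:
- compound 1 `CNC(=O)Nc1ccc(-c2nc(N3CC4CCC(C3)O4)c3cnn(CCN(C)C)c3n2)cc1`: 0.0833 h
- compound 2 `CNC(=O)Nc1ccc(-c2nc(N3CC4CCC(C3)O4)c3cnn(C4CCC5(CC4)OCCCO5)c3n2)cc1`: > 0.5 h (a limit)
- compound 3 `CNC(=O)Nc1ccc(-c2nc(N3CC4CCC(C3)O4)c3cnn([C@H]4CC[C@@H](OC)CC4)c3n2)cc1`: 0.283 h

Compound 3 holds the higher of the two actual numbers, with a 3.4-fold higher number from compound 1 to compound 3 (0.53 log units; beyond the scatter). The entry for compound 2 is a limit, and an at least 1.7-fold lower number from compound 2 to compound 3 (0.24 log units; that floor lies within the scatter).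

Compound 4 `CNC(=O)Nc1ccc(-c2nc(N3CC4CCC(C3)O4)c3cnn([C@H]4CC[C@H](OC)CC4)c3n2)cc1` departs from compound 3 as follows: the two compounds have the same atoms and bonds; at least one stereo element is drawn with a configuration in one of them and without one in the other: 2 of 4 stereo elements differ; a stereocentre at a saturated ring carbon is drawn s in compound 3 and r in compound 4; a stereocentre at a saturated ring carbon is drawn s in compound 3 and r in compound 4. The measured steps, including an at least 6.0-fold higher number from compound 1 to compound 2 (0.77 log units; beyond the scatter), all replace the group on the aromatic nitrogen, and none changes stereocentres alone. They therefore set no size for this change, and no step beyond the scatter is expected in this assay. The expected change is a 1.1-fold higher number from compound 3 to compound 4 (0.03 log units; within the scatter). For compound 4 the estimated half-life is 0.3 h, within a range of 0.15 h to 0.6 h.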

Compound 4, half-life: > 0.5 h
Compound 4: only a limit was reported; the forecaster's own chance of this, stated with the estimate: 15%; middle value at least 1.6-fold (0.22 log units) away from the limit.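

Redrawing the two stereocentres while the atoms and bonds stay the same gives an at least 1.7-fold higher number from compound 3 to compound 4 (0.24 log units; that floor lies within the scatter), the first sign in this assay that this position may respond to configuration alone, though that floor does not clear the scatter. The entry for compound 4, > 0.5 h, is a limit. With the same 4-methoxycyclohexyl in place of 2-(dimethylamino)ethyl, this configuration gives an at least 6.0-fold higher number from compound 1 to compound 4 (0.77 log units; beyond the scatter).

From the compounds shown here alone, the step between compound 2 and compound 4 cannot be read, and the true size of the stereocentre step stays open: the limit of > 0.5 h in this assay, at which 2 of the 4 values shown sit. Whether an amine in place of the methoxy would respond to the same redrawing also remains open.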